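From 4-Chlorophenyl to 2-Bromophenyl in a Barely Toxic Series

The source may hold more compounds than are shown below. What is called first, only, known or untested is meant among the compounds shown, and "the series" means these compounds.

Three related compounds have been tested so far in an ADME assay on cells (Epithelial cell, Homo sapiens) for antiproliferative activity, read by MTT assay, with a stated time of 48 h (on this read-out higher numbers stand for weaker inhibition and lower numbers for stronger inhibition), and only one of them gives a true number. Compound 1 (`COC(=O)/C(=C/c1ccccc1)CN1C(=O)[C@@H](OC)[C@H]1c1ccc(Cl)cc1`) reaches 37900 nM in this test. Compound 2 (`CCOC(=O)/C(=C/c1ccccc1)CN1C(=O)[C@@H](OC)[C@H]1c1ccc(Cl)cc1`) has no single number, and its entry of "not toxic" (no number reported) means that it cannot be placed on the scale. Compound 3 (`COC(=O)/C(=C/c1ccccc1)CN1C(=O)[C@@H](OC)[C@H]1c1ccc(OC)cc1`) is the further entry without a number, with the same result of "not toxic" (no number reported) on record.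

Compound 4 (`CCOC(=O)/C(=C/c1ccccc1)CN1C(=O)[C@@H](OC)[C@H]1c1ccccc1Br`) has not yet been measured in this assay and differs from compound 2 in one place. The change is 2-bromophenyl in place of 4-chlorophenyl on a saturated ring carbon and it puts 2-bromophenyl in place of 4-chlorophenyl on a saturated ring carbon.

For the measured compounds named here, no measured pair in this small set shows what such a swap does, so any expectation here is a cautious one. Going by the values given here, the closest guide is compound 2 with its "not toxic" (no number reported) entry, together with compound 1 at 37900 nM as the only number available. A step beyond the scatter in either direction is not expected, and another entry without a number is quite possible. For compound 4 the estimated value is 50000 nM with an expected range from 20000 nM to 120000 nM in this test.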

Compound 4, half-maximal inhibitory concentration: 66600 nM
For compound 4 the middle estimate is 1.3-fold (0.12 log units) below the measured one; measured number inside the range.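

For the compounds shown here, compound 4 now has a number in this assay, but compound 2 has no single number, so no step between compound 2 and compound 4 can be read. The compounds shown leave open how 2-bromophenyl in place of 4-chlorophenyl changes this read-out. Nothing measured here offers an explanation for the result of compound 4.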